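Compound 1 and a single drawn stereocentre

This account rests on a few compounds, and the source may have more. Where it says the series, first, only, none or still open, it means among the compounds named here.

- compound 1 `CC(CC(=O)O)CC(=O)c1c(CCCCCCc2ccccc2)n(C)c2ccc(Cl)cc12` gives 108000 nM as its value
- compound 2 `CC(CC(=O)O)CC(=O)n1c(CCCCCc2ccccc2)cc2ccc(Cl)cc21` gives 55000 nM as its value

In an ADME assay on the whole organism (plasma) for pharmacokinetics, with Cynomolgus monkey (Macaca fascicularis) as the target, read by HPLC, at a dose of 30 mg/kg by the oral route (on this read-out lower numbers stand for lower exposure and higher numbers for higher exposure at the dose given), these two numbers lie within the usual scatter of each other, so compound 1 stands level with compound 2 and neither can be ranked.

Compound 3 `C[C@H](CC(=O)O)CC(=O)c1c(CCCCCCc2ccccc2)n(C)c2ccc(Cl)cc12` is the next to be measured. It has the same atoms and bonds as compound 1 (the two compounds have the same atoms and bonds; at least one stereo element is drawn with a configuration in one of them and without one in the other: 1 of 1 stereo elements differ; a stereocentre at a saturated chain carbon is drawn without a configuration in compound 1 and S in compound 3). A stereocentre at a saturated chain carbon is drawn without a configuration in compound 1 and S in compound 3.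

Among the measured compounds shown here, no measured pair shows a change of this kind, so there is no step to lean on. In this assay no change beyond the scatter is expected, in either direction. The expected step of a 1.0-fold lower number from compound 1 to compound 3 (0.01 log units; within the scatter) is therefore small. The estimate starts from compound 1 (108000 nM) and stays close to it. Compound 3 is estimated at 105000 nM (52000 nM to 210000 nM).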

Compound 3, maximal plasma concentration: 106000 nM
Estimate against measurement, compound 3: 1.0-fold (0.00 log units) below, and the stated range covers the measured number.
By their numbers in this assay, from the lowest: compounds 2, 3 and 1 (each within the scatter of the next).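

In this assay, among the compounds shown here, this is the first pair that differs only at a stereocentre, here at a saturated chain carbon, and it gives a 1.0-fold lower number from compound 1 to compound 3 (0.01 log units; within the scatter) as its step. Drawing this carbon as S therefore leaves the maximal plasma concentration level with that of the compound drawn without a configuration, so this one pair gives no sign that the drawn S configuration matters for exposure in the monkey at this dose. The comparison rests on a single structural difference: the fact that one of compounds 1 and 3 is drawn with a defined configuration and the other without, at the place where they differ

The compounds shown leave open how a compound drawn R at this stereocentre would stand in this assay. They also leave open whether a hydroxyl group on this same chain carbon would keep the exposure level with that of compound 3 (106000 nM).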